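Methoxy Addition to a Chromanol Core: An Expected Step

The source may hold more compounds than are shown below. What is called first, only, known or untested is meant among the compounds shown, and "the series" means these compounds.

Measured compounds:
compound 1 `CC1(C)COc2ccccc2C1O`: 24.3%
compound 2 `COc1cccc2c1C(=O)C(C)(C)CO2`: 12.1%
compound 3 `CC1(C)COc2ccccc2C1=O`: 9.7%

Of the compounds shown here, three have been tested in an assay on BTI cells for inhibition of Amine oxidase [flavin-containing] A (Homo sapiens), read by fluorescence, with a stated time of 20 min, tested at 1 uM; on this read-out lower numbers stand for less inhibition and higher numbers for more inhibition at the one concentration tested (going by the name of the read-out). Compound 1 gives 24.3%, the highest of the three numbers; compound 2 gives 12.1% and compound 3 gives 9.7%, both beyond the scatter below compound 1. The difference between the core of compound 1 and the core of compound 3 is not broken down here.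

One structural change is seen twice. From compound 3 to compound 2 it is methoxy in place of hydrogen on an aromatic carbon and the measured step is a number 2.4 percentage points higher from compound 3 to compound 2 (within the scatter). The same change is made from compound 1 to compound 4 `COc1cccc2c1C(O)C(C)(C)CO2`: methoxy in place of hydrogen on an aromatic carbon

Since the earlier step was within the scatter, compound 4 is expected to stay near compound 1, with an expected step of a number 1.7 percentage points higher from compound 1 to compound 4 (within the scatter) resting on a number 2.4 percentage points higher from compound 3 to compound 2 (within the scatter). The estimate for compound 4 in this assay is 26%, expected to lie between 14% and 38%.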

Compound 4, a percentage reported as inhibition, at one concentration (the size of the read-out at that concentration, not a potency): 11.5%
Beside the measured number, compound 4's estimate is 14.5 percentage points above it, and the stated range ends above it.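

Tested in this assay on the core of compound 1, methoxy in place of hydrogen on an aromatic carbon gave a number 12.8 percentage points lower from compound 1 to compound 4 (beyond the scatter) and so did not repeat the small step seen on the core of compound 3. The same change therefore did not carry from one core to the other in this series, and the two steps differ: the same change on two cores in this assay, a number 2.4 percentage points higher (within the scatter) from compound 3 to compound 2 and a number 12.8 percentage points lower (beyond the scatter) from compound 1 to compound 4, 15.2 percentage points apart, beyond the scatter of two such steps. This shows that a step read on one of these cores cannot simply be transferred to the other, but with a single pair on each core it does not show which feature of the cores sets the steps apart, nor how the change would behave on any further core.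

The compounds shown leave open whether an amine, a carboxylic acid or a longer chain in place of the methoxy would follow the same split between the two cores. They also leave open whether the gap between the steps would hold at other concentrations, since each number here comes from one concentration only.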